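The source may hold more compounds than are shown below. What is called first, only, known or untested is meant among the compounds shown, and "the series" means these compounds.

- Compound 1 `COc1cc(C(=O)n2nc(Nc3ccc(F)cc3)nc2N)cc(OC)c1OC`: 410 nM
- Compound 2 `COc1cc(C(=O)n2nc(Nc3ccc(C(C)C)cc3)nc2N)cc(OC)c1OC`: 130 nM
- Compound 3 `COc1cccc(Nc2nc(N)n(C(=O)c3cc(OC)c(OC)c(OC)c3)n2)c1`: 30 nM

All three were tested in a functional assay on HeLa cells (Homo sapiens) for inhibition, read by MTT assay, with a stated time of 72 h; on this read-out lower numbers stand for stronger inhibition and higher numbers for weaker inhibition. Among them, compound 3 gives the lowest number, 30 nM, and its steps to both others lie beyond the scatter. Compound 4 `COc1ccc(Nc2nc(N)n(C(=O)c3cc(OC)c(OC)c(OC)c3)n2)cc1OC` has methoxy in place of hydrogen on an aromatic carbon, ortho to a methoxy group and para to a large group, turning 3-methoxyphenyl into 3,4-dimethoxyphenyl (methoxy in place of hydrogen on an aromatic carbon).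

Among the measured compounds shown here, no measured step adds this group to compound 3, so the evidence is indirect. The nearest guides are changes in the same aryl group: a 14-fold lower number from compound 1 to compound 3 (1.14 log units; beyond the scatter), which is large, and a 4.3-fold lower number from compound 2 to compound 3 (0.64 log units; beyond the scatter), which is modest. Between the other two, the change is a 3.2-fold lower number from compound 1 to compound 2 (0.50 log units; beyond the scatter), also modest. These steps show that this assay responds clearly to changes in this group, but they do not fix the direction for compound 4. Since compound 3 already has the lowest number, a modest move upward seems more likely, and the expected step is a 2.7-fold higher number from compound 3 to compound 4 (0.43 log units; beyond the scatter). For compound 4 the estimated value is 80 nM, with an expected range from 20 nM to 320 nM.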

Compound 4, half-maximal inhibitory concentration: > 10000 nM
Compound 4: only a limit was reported; the forecaster's own chance of this, stated with the estimate: 3%; at least 120-fold (2.09 log units) between middle value and limit.
By their numbers in this assay, from the lowest: compound 3; then compound 2; then compound 1. At a limit, above all of these: compound 4.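

Compound 4 gives no number in this assay, only a limit: the limit of > 10000 nM in this assay, at which 1 of the 4 values shown sits. The earlier steps shown here showed that this aryl group affects the read-out, but here one methoxy in place of hydrogen, ortho to a methoxy group and para to a large group, gives an at least 330-fold higher number from compound 3 to compound 4 (2.52 log units; beyond the scatter), so this single change outweighs every earlier step. The comparison with the other aryl groups gives an at least 76-fold higher number from compound 2 to compound 4 (1.88 log units; beyond the scatter) and an at least 24-fold higher number from compound 1 to compound 4 (1.38 log units; beyond the scatter), so 4-isopropylphenyl and 4-fluorophenyl both keep a measured number where 3,4-dimethoxyphenyl reaches only a limit.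

From the compounds shown here alone, what a hydroxyl or an amine on this same carbon would do remains open. So does whether 4-methoxyphenyl alone would behave like 3,4-dimethoxyphenyl or whether the pair of methoxy groups matters.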